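The source may report more compounds than this note shows. Statements on the series, on what has been measured and on what is new or still open speak of the compounds shown alone.

Working notes on the series in a functional assay on RAW264.7 cells (Mus musculus) for inhibition, read by fluorescence, with stated times of 1 h, 24 h and 30 min; on this read-out higher numbers stand for weaker inhibition and lower numbers for stronger inhibition. Compound 1 `O=C(/C=C/c1ccccc1F)c1ccccc1` returns only a limit of the assay, > 10000 nM. Compound 2 `O=C(/C=C/c1cccc(F)c1)c1ccccc1` likewise returns only a limit, > 10000 nM. Compound 3 `O=C(/C=C/c1ccccc1OC(F)(F)F)c1ccccc1` also returns only a limit, > 10000 nM. The difference between the cores of compound 1 and compound 2 is not broken down here. The change from compound 1 to compound 3 is trifluoromethoxy in place of fluoro on an aromatic carbon, and its step is a step that the two limits leave unreadable from compound 1 to compound 3, because both ends sit at the limit of > 10000 nM in this assay, at which 3 of the 3 values shown sit. Compound 4 `O=C(/C=C/c1cccc(OC(F)(F)F)c1)c1ccccc1` carries the same kind of change relative to compound 2, (trifluoromethoxy in place of fluoro on an aromatic carbon); the place differs, ortho to a large group in compound 3 but meta to a large group in compound 4. With compound 1, compound 2 and compound 3 all at the limit of > 10000 nM in this assay, at which 3 of the 3 values shown sit, the step from compound 2 to compound 4 is expected to be a step that the limit leaves unreadable from compound 2 to compound 4. Compound 4 is estimated to give 15000 nM, most likely again as a limit rather than a number.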

Compound 4, half-maximal inhibitory concentration: > 10000 nM
Compound 4 ended at the assay's limit (the forecaster's own chance of this, stated with the estimate: 85%); the middle value is on the limit's open side.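

No new step can be read between compound 2 and compound 4 in this assay, because both ends sit at the same limit: the limit of > 10000 nM in this assay, at which 4 of the 4 values shown sit.

The compounds shown leave open how fluoro and trifluoromethoxy compare once a value falls inside the measurable range of this assay.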